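Trimming the amide aryl group: from substituted to plain phenyl

The source may report more compounds than this note shows. Statements on the series, on what has been measured and on what is new or still open speak of the compounds shown alone.

Measured so far:
compound 1 `COc1cc(-c2nn(-c3cccc(NC(=O)Nc4ccc(Cl)c(Cl)c4)c3)cc2-c2ccncc2)ccc1Cl` — 3100 nM
compound 2 `COc1cc(-c2nn(-c3cccc(NC(=O)c4ccc(Cl)c(C(F)(F)F)c4)c3)cc2-c2ccncc2)ccc1Cl` — 13400 nM

In a functional assay on NCI-H522 cells (Homo sapiens) for inhibition, read by sulforhodamine B assay, with a stated time of 48 h (on this read-out lower numbers stand for stronger inhibition of growth and higher numbers for weaker inhibition of growth), compound 2 stands with the higher of the two numbers, while compound 1 sits a clear step lower. For the measured compounds named here, the one measured step, a 4.3-fold higher number from compound 1 to compound 2 (0.64 log units; beyond the scatter), exchanged a urea-type linkage for an amide-type one and does not touch the aryl part that changes next.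

Compound 3 `COc1cc(-c2nn(-c3cccc(NC(=O)c4ccccc4)c3)cc2-c2ccncc2)ccc1Cl` differs from compound 2 by phenyl in place of 4-chloro-3-(trifluoromethyl)phenyl on a carbonyl carbon. Going by the values given here, no measured pair alters only this aryl group, so the direction of the step rests on the change itself and on the fact that compound 2 already gives the weakest result seen. The expected outcome is a modest move toward weaker inhibition of growth, a 1.9-fold higher number from compound 2 to compound 3 (0.27 log units; within the scatter), though a number close to that of compound 2 would not be surprising. Compound 3 is therefore estimated at 25000 nM, with a likely range from 8000 nM to 80000 nM in this assay.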

Compound 3, concentration for total growth inhibition: > 100000 nM
Compound 3 gave a limit, no number; the forecaster's own chance of this, stated with the estimate: 15%; middle value at least 4.0-fold (0.60 log units) from the limit.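

Compound 3 shows that the substituted aryl group on this amide carbonyl cannot simply be trimmed away: replacing 4-chloro-3-(trifluoromethyl)phenyl with phenyl gives an at least 7.4-fold higher number from compound 2 to compound 3 (0.87 log units; beyond the scatter) in this assay, which means weaker inhibition of growth. The same plain phenyl, set against the (3,4-dichlorophenyl)amino group on the carbonyl carbon, gives an at least 32-fold higher number from compound 1 to compound 3 (1.50 log units; beyond the scatter), a large step. Going by these compounds, compound 3 gave a limit of the assay rather than a number, so the true size of both steps stays unknown: the limit of > 100000 nM in this assay, at which 1 of the 3 values shown sits.

On these data alone, it remains open whether a lone chlorine or a lone trifluoromethyl on the phenyl ring would be enough to bring the activity back. Also open, as far as these compounds go, is how an amine or a carboxylic acid on that ring would behave.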